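The compounds below may be only part of what the source reports. "The series", "measured", "known", "first", "only" and "open" are said of these compounds alone.

Measured in a functional assay on HCT-116 cells (Homo sapiens) for cytotoxicity, read by fluorescence, with a stated time of 72 h; a higher number here means a weaker inhibitor, a lower number a stronger inhibitor:

- Compound 1 `CSc1nc(NCc2ccc(-c3ccccn3)cc2)c2[nH]nc(C(C)C)c2n1`: 2800 nM
- Compound 2 `CC(C)c1n[nH]c2c(NCc3ccc(-c4ccccn4)cc3)nc(NCCO)nc12`: 27 nM
- Compound 3 `CC(C)c1n[nH]c2c(NCc3ccc(-c4ccccn4)cc3)nc(NCCN)nc12`: 227 nM

Compound 3 has the second highest of these three numbers. The steps that place it are a 12-fold lower number from compound 1 to compound 3 (1.09 log units; beyond the scatter) and an 8.4-fold higher number from compound 2 to compound 3 (0.92 log units; beyond the scatter), and both lie beyond the scatter.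

The next compound, compound 4 `CC(C)c1n[nH]c2c(NCc3ccc(-c4ccccn4)cc3)nc(N3CCNCC3)nc12`, has not yet been measured. It carries piperazin-1-yl in place of (2-aminoethyl)amino on an aromatic carbon.

Among the measured compounds shown here, no measured step makes this exact replacement, so the evidence is indirect. The same aromatic carbon changes the number strongly in two steps, a 100-fold lower number from compound 1 to compound 2 (2.02 log units; beyond the scatter) and a 12-fold lower number from compound 1 to compound 3 (1.09 log units; beyond the scatter), but each of these starts from methylsulfanyl. The closest comparison is the change at the end of the chain, an 8.4-fold higher number from compound 2 to compound 3 (0.92 log units; beyond the scatter), which shows that a smaller edit of this substituent can also matter. Compound 4 keeps both nitrogen atoms of the group in compound 3, so a large step seems unlikely. The data do not settle the direction, and the expectation is a step no larger than modest, quite possibly none beyond the scatter.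

The expected change is a 1.1-fold lower number from compound 3 to compound 4 (0.05 log units; within the scatter). For compound 4 the estimated value is 200 nM, with an expected range from 55 nM to 700 nM.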

Compound 4, half-maximal inhibitory concentration: 88 nM
The estimate for compound 4 lay 2.3-fold (0.36 log units) above the measured number; the range from low to high includes it.
By their numbers in this assay, from the lowest: compound 2; then compound 4; then compound 3; then compound 1.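

In this assay, closing the open (2-aminoethyl)amino group into piperazin-1-yl gives a 2.6-fold lower number from compound 3 to compound 4 (0.41 log units; beyond the scatter) and shows that this aromatic carbon still responds when the two nitrogen atoms remain and the chain gives way to a six-membered non-aromatic ring. The ring does not match the (2-hydroxyethyl)amino group, with a 3.3-fold higher number from compound 2 to compound 4 (0.51 log units; beyond the scatter) in this comparison, but it remains far from methylsulfanyl, with a 32-fold lower number from compound 1 to compound 4 (1.50 log units; beyond the scatter) as the third replacement of that group to lower the number, so a ring as well as an open chain can do this here. Nothing measured here explains why the ring lowers the number relative to the open chain or why it falls short of the (2-hydroxyethyl)amino group.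

The compounds shown leave open how a morpholin-4-yl ring, with oxygen in place of the second nitrogen, would compare with piperazin-1-yl, a question raised by an 8.4-fold higher number from compound 2 to compound 3 (0.92 log units; beyond the scatter) in the open chains. As far as these compounds go, it also remains open whether a methyl group on the second ring nitrogen or a longer chain would move the number away from that of compound 4 at 88 nM and towards that of compound 2 at 27 nM in this assay.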